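Bromo for Chloro on Two Related Hydrazone Cores

The source may report more compounds than this note shows. Statements on the series, on what has been measured and on what is new or still open speak of the compounds shown alone.

Compound 1 `Cn1nnnc1SCC(=O)N/N=C/c1ccccc1Cl` and compound 2 `Cn1nnnc1SCC(=O)N/N=C/c1cccc(Cl)c1` are built from the same atoms joined differently; how their two cores differ is not broken down here. In an ADME assay on NIH3T3 cells (Mus musculus) for cytotoxicity, read by XTT assay, with a stated time of 24 h (on this read-out higher numbers stand for weaker inhibition and lower numbers for stronger inhibition), compound 1 gives > 10000000 nM, which is a limit of the assay and not a number, the case described by the limit of > 10000000 nM in this assay, at which 1 of the 3 values shown sits. In this assay compound 2 gives 7500000 nM. Compound 3 `Cn1nnnc1SCC(=O)N/N=C/c1ccccc1Br` differs from compound 1 by bromo in place of chloro on an aromatic carbon. In this assay compound 3 gives 20000 nM, and the step is an at least 500-fold lower number from compound 1 to compound 3 (2.69 log units; beyond the scatter).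

Compound 4 `Cn1nnnc1SCC(=O)N/N=C/c1cccc(Br)c1` has not yet been measured; it differs from compound 2 by bromo in place of chloro on an aromatic carbon. The two places are not the same: in compound 3 the bromo sits ortho to a large group, in compound 4 meta to a large group, so this is the same kind of change, not the same change. In this assay the step is expected to be a 25-fold lower number from compound 2 to compound 4 (1.40 log units; beyond the scatter), resting on the measured step of an at least 500-fold lower number from compound 1 to compound 3 (2.69 log units; beyond the scatter), which itself starts from a limit and so gives only a floor. Compound 4 is therefore estimated at 300000 nM, with a range from 15000 nM to 7500000 nM.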

Compound 4, half-maximal inhibitory concentration: 316000 nM
The estimate for compound 4 lay 1.1-fold (0.02 log units) below the measured number; measured number inside the range.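

In this assay, bromo in place of chloro on an aromatic carbon lowers the number on both cores, and the new step is a 24-fold lower number from compound 2 to compound 4 (1.38 log units; beyond the scatter). The direction of the change therefore carried over from one core to the other, but its size did not: the same change on two cores in this assay, an at least 500-fold lower number (2.69 log units; beyond the scatter) from compound 1 to compound 3 and a 24-fold lower number (1.38 log units; beyond the scatter) from compound 2 to compound 4, at least 21-fold (1.32 log units) apart, beyond the scatter of two such steps. On these data alone, these two steps do not give a rule for other cores, and the true size of the earlier step and of the gap between the two stays unknown, for that step starts from a value that is a limit of the assay and not a number: the limit of > 10000000 nM in this assay, at which 1 of the 4 values shown sits.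

The compounds shown leave open how a methyl, a methoxy or a nitrile group on the same aromatic carbon would compare with chloro and bromo. They also leave open how a plain hydrogen there would read, and whether the step from chloro to bromo keeps its direction on any core beyond these two.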